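Replacing One Aromatic Ring and the Spread into Tissues

The source may report more compounds than this note shows. Statements on the series, on what has been measured and on what is new or still open speak of the compounds shown alone.

Compound 1 `Cc1ccccc1[C@@]1(O)C[C@H](C(=O)Nc2ccc(-n3ccccc3=O)cn2)N(C(=O)Nc2ccc(Cl)cc2)C1` was examined in an in vivo ADME assay on the whole organism for pharmacokinetics, with Rattus norvegicus as the target, using cassette dosing (on this read-out lower numbers stand for narrower distribution and higher numbers for wider distribution into tissues), where compound 1 gives 0.468 L/kg. For the measured compounds named here, only one other compound has a number so far: compound 2 `O=C(Nc1ccc(-n2ccccc2=O)cn1)[C@H]1C[C@](O)(c2ccccc2Cl)CN1C(=O)Nc1ccc(Cl)cc1`, which carries a chloro in place of the methyl on an aromatic carbon, and in this assay compound 2 gives 0.923 L/kg. Going by the values given here, compound 1 thus shows the smaller of the two numbers, yet the single step joining them, a 2.0-fold higher number from compound 1 to compound 2 (0.29 log units; within the scatter), stays inside the usual scatter, so the two results cannot be told apart with confidence.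

Compound 3 `O=C(Nc1ccc(-n2ccccc2=O)cn1)[C@H]1C[C@](O)(c2ccc(F)c(F)c2)CN1C(=O)Nc1ccc(Cl)cc1` has not yet been measured. Its difference from compound 1 is 3,4-difluorophenyl in place of 2-methylphenyl on a saturated ring carbon. Among the compounds with values here, the one measured step also exchanged a group on an aromatic ring and moved the number only within the scatter, so a similarly modest outcome is expected here. The step from compound 1 to compound 3 is estimated as a 1.3-fold higher number from compound 1 to compound 3 (0.11 log units; within the scatter), with compound 3 expected at 0.6 L/kg, and its value is expected to fall between 0.35 L/kg and 1.1 L/kg in this assay.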

Compound 3, volume of distribution at steady state: 1.6 L/kg
Compound 3: the middle estimate sits 2.7-fold (0.43 log units) below what was measured; the measured number lies above the stated range.
By their numbers in this assay, from the lowest: compounds 1, 2 and 3 (each within the scatter of the next, the first and the last beyond it).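

At this position, on a saturated ring carbon of the five-membered ring, exchanging one aromatic group for another can move the number beyond the scatter: 3,4-difluorophenyl in place of 2-methylphenyl gives a 3.4-fold higher number from compound 1 to compound 3 (0.53 log units; beyond the scatter) in this assay, a modest step but the first of this size in the series. The same incoming group in place of 2-chlorophenyl gives a 1.7-fold higher number from compound 2 to compound 3 (0.24 log units; within the scatter), so the clear separation holds only against compound 1, while compound 3 and compound 2 cannot be told apart with confidence. Nothing available here accounts for the step from compound 1 to compound 3.

The compounds shown leave open how much each fluorine contributes, since neither 3-fluorophenyl nor 4-fluorophenyl appears among them to separate the two ring sites from each other. They also leave open what the number would do with a phenyl ring bearing an amine or a carboxylic acid at this ring carbon, or with a saturated cyclohexyl group in place of the aromatic ring.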